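This account rests on a few compounds, and the source may have more. Where it says the series, first, only, none or still open, it means among the compounds named here.

Working notes on the series. For the measured compounds named here, compound 1 `O=C1c2c[n+]([O-])c3ccccc3c2C(=O)c2c1c1ccccc1n2CCCCN1CCNCC1` has been measured in a functional assay on MCF7 cells (Homo sapiens) for cytotoxicity, read by MTT assay, with a stated time of 72 h (on this read-out lower numbers stand for stronger inhibition and higher numbers for weaker inhibition), and gives 12000 nM, the higher of the two numbers so far; compound 2 `O=C1c2c[n+]([O-])c3ccccc3c2C(=O)c2c1c1ccccc1n2Cc1cn([C@@H]2O[C@H](CO)[C@@H](O)[C@H](O)[C@H]2O)nn1` gives 590 nM in this assay, the lower one, and the gap between them lies beyond the scatter. Compound 3 `CN1CCN(CCCCCn2c3c(c4ccccc42)C(=O)c2c[n+]([O-])c4ccccc4c2C3=O)CC1` is not yet measured. It differs from compound 1 by (4-methylpiperazin-1-yl)methyl in place of piperazin-1-yl on a saturated chain carbon, four bonds along the chain from an aromatic nitrogen. Going by the values given here, no measured pair shows this change, so the expected step of a 1.5-fold lower number from compound 1 to compound 3 (0.18 log units; within the scatter) is put as small, not beyond the scatter, and the expected value for compound 3 in this assay is 8000 nM, with a range from 2500 nM to 25000 nM.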

Compound 3, half-maximal inhibitory concentration: 1260 nM
For compound 3 the middle estimate is 6.3-fold (0.80 log units) above the measured one; measured number outside the range, below it.
By their numbers in this assay, from the lowest: compound 2; then compound 3; then compound 1.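

On a saturated chain carbon, four bonds along the chain from an aromatic nitrogen, the number in this assay responds to this change: (4-methylpiperazin-1-yl)methyl in place of piperazin-1-yl gives a 9.5-fold lower number from compound 1 to compound 3 (0.98 log units; beyond the scatter). The change lengthens the chain and removes the hydrogen-bond donor together, so this single pair cannot divide the step between them. No available evidence bears on the origin of the step.

Still open, as far as these compounds go, is which part of the change matters, a question that 4-(4-methylpiperazin-1-yl)butyl and 5-(piperazin-1-yl)pentyl on the same core would address. Also open, from the compounds shown here alone, is how a morpholine ring in place of the piperazine ring would read.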